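The source may report more compounds than this note shows. Statements on the series, on what has been measured and on what is new or still open speak of the compounds shown alone.

Measured so far:
compound 1 `CC(C)C(Cc1nnc[nH]1)c1ccc(-c2ccc3cccc(F)c3c2)[nH]c1=O` — < 0.0667 h
compound 2 `CC(C)C(c1ccc(-c2ccc3cccc(F)c3c2)[nH]c1=O)N1CCCCC1=O` — 0.0967 h
compound 3 `CC(C)C(c1ncc[nH]1)c1ccc(-c2ccc3cccc(F)c3c2)[nH]c1=O` — < 0.0667 h

In an ADME assay on microsomes from liver (Mus musculus) for metabolic stability (on this read-out higher numbers stand for a longer-lived compound and lower numbers for a shorter-lived compound), compound 1 gives < 0.0667 h, which is a limit of the assay and not a number. Compound 2 gives 0.0967 h. Compound 3 also gives only a limit, < 0.0667 h, so that (the limit of < 0.0667 h in this assay, at which 2 of the 3 values shown sit). Hence a step that the two limits leave unreadable from compound 1 to compound 3, while an at least 1.4-fold lower number from compound 2 to compound 3 (0.16 log units; that floor lies within the scatter). Compound 4 `Cc1c[nH]c(C(c2ccc(-c3ccc4cccc(F)c4c3)[nH]c2=O)C(C)C)n1` differs from compound 3 by methyl in place of hydrogen on an aromatic carbon. Going by the values given here, no measured step touches such a change; each of them exchanges the whole group on the saturated chain carbon. Compound 4 is therefore expected to show a step that the limit leaves unreadable from compound 3 to compound 4, nothing beyond the scatter, and most likely to return a limit again. The estimate for compound 4 in this assay is 0.06 h, with a range from 0.03 h to 0.12 h.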

Compound 4, half-life: < 0.0667 h
Compound 4 ended at the assay's limit (the forecaster's own chance of this, stated with the estimate: 60%); the middle value does not contradict the limit.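

In this assay compound 4 returns a limit and not a number, so methyl on this aromatic carbon brings the series no closer to a readable value: the limit of < 0.0667 h in this assay, at which 3 of the 4 values shown sit. The steps from compound 3 to compound 4 and from compound 1 to compound 4 cannot be read. Going by these compounds alone, the one readable step is an at least 1.4-fold lower number from compound 2 to compound 4 (0.16 log units; that floor lies within the scatter).

Going by these compounds, how far compound 3 and compound 4 lie past the limit stays open, and with it any effect of the methyl group. Also open, on these data alone, is whether trifluoromethyl or a carboxylic acid at this place would give a number rather than a limit.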